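This account rests on a few compounds, and the source may have more. Where it says the series, first, only, none or still open, it means among the compounds named here.

Compound 1, `CC(O)(CSc1cccc(C(F)(F)F)c1)C(=O)Nc1cccc(S(F)(F)(F)(F)F)c1`, and compound 2, `CC(O)(CSc1cc(C(F)(F)F)cc(C(F)(F)F)c1)C(=O)Nc1cccc(S(F)(F)(F)(F)F)c1`, share one core and were both tested in a functional assay on CWR22R cells (Homo sapiens) for antiproliferative activity, read by propidium iodide staining, with a stated time of 96 h; on this read-out higher numbers stand for weaker inhibition and lower numbers for stronger inhibition. Compound 1 gives 12900 nM, and compound 2 gives 4400 nM. The change between them is trifluoromethyl in place of hydrogen on an aromatic carbon, and it produced a 2.9-fold lower number from compound 1 to compound 2 (0.47 log units; beyond the scatter).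

Compound 3, `CC(O)(COc1ccc(C#N)cc1)C(=O)Nc1ccc(S(F)(F)(F)(F)F)cc1`, rests on a different core; the difference between the two cores is not broken down here. In this assay compound 3 gives 26100 nM, the highest of the three numbers.

Compound 4, `CC(O)(COc1ccc(C#N)cc1C(F)(F)F)C(=O)Nc1ccc(S(F)(F)(F)(F)F)cc1`, is not yet measured. It arises from compound 3 by trifluoromethyl in place of hydrogen on an aromatic carbon. Going by the values given here, this is the same kind of change as the one from compound 1 to compound 2, but the surroundings differ: in compound 2 the new group is meta to a large group and meta to a trifluoromethyl group, whereas in compound 4 it is ortho to a large group and meta to a cyano group.

For compound 4 the step is estimated at a 2.2-fold lower number from compound 3 to compound 4 (0.34 log units; beyond the scatter), set beside a 2.9-fold lower number from compound 1 to compound 2 (0.47 log units; beyond the scatter) and tempered because a 2.9-fold lower number from compound 1 to compound 2 (0.47 log units; beyond the scatter) arose in different surroundings. Compound 4 is therefore expected to give 12000 nM, with a likely range from 5000 nM to 30000 nM.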

Compound 4, half-maximal inhibitory concentration: 13800 nM
Estimate against measurement, compound 4: 1.2-fold (0.06 log units) below; the range from low to high includes it.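

In this assay the addition of trifluoromethyl on the core of compound 3 gives a 1.9-fold lower number from compound 3 to compound 4 (0.28 log units; within the scatter), so this step cannot be told apart from the scatter of repeated measurements. Set beside the step on the other core, it gives no sign that the change acts differently on the two cores: the same change on two cores in this assay, a 2.9-fold lower number (0.47 log units; beyond the scatter) from compound 1 to compound 2 and a 1.9-fold lower number (0.28 log units; within the scatter) from compound 3 to compound 4, 1.6-fold (0.19 log units) apart, within the scatter of two such steps. This does not show that the change carries over reliably, for only a 2.9-fold lower number from compound 1 to compound 2 (0.47 log units; beyond the scatter) lies beyond the scatter, the comparison rests on just two pairs, and the new group has different surroundings in each.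

The compounds shown leave open whether a chlorine atom or a methoxy group in place of the trifluoromethyl group, on the same aromatic carbon of compound 3, would give a step of similar size. They also leave open how the change would behave on a third core, such as one with an amine in place of the hydroxyl group.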